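Trading one chlorinated aryl amide for another

The source may report more compounds than this note shows. Statements on the series, on what has been measured and on what is new or still open speak of the compounds shown alone.

Compound 1 `COc1cc(-c2nn(-c3ccc(NC(=O)Nc4ccc(Cl)c(C(F)(F)F)c4)cc3)cc2-c2ccncc2)ccc1Cl` gives 14000 nM in a functional assay on A375P cells (Homo sapiens) for antiproliferative activity, read by MTT assay, with a stated time of 48 h; on this read-out lower numbers stand for stronger inhibition and higher numbers for weaker inhibition.
Compound 2 `COc1cc(-c2nn(-c3ccc(NC(=O)c4cc(Cl)cc(Cl)c4)cc3)cc2-c2ccncc2)ccc1Cl` reaches only the assay limit in this assay, > 20000 nM, which is a limit and not a number.

Compound 2 therefore stands at the weak end of what has been measured, outside the range the assay reports. Compound 3 `COc1cc(-c2nn(-c3ccc(NC(=O)c4ccc(Cl)c(C(F)(F)F)c4)cc3)cc2-c2ccncc2)ccc1Cl` differs from it by 4-chloro-3-(trifluoromethyl)phenyl in place of 3,5-dichlorophenyl on a carbonyl carbon. Going by the values given here, the single measured step, an at least 1.4-fold higher number from compound 1 to compound 2 (0.15 log units; that floor lies within the scatter), alters both the linker and the aryl group at once, so it bears only loosely on this change; compound 3 pairs the aryl group of compound 1 with the amide of compound 2. No step beyond the scatter is expected in this assay, and the estimated step of a number no higher from compound 2 to compound 3 (the limit leaves the size open) starts from a limit. Compound 3 is expected near 20000 nM, with a range from 7000 nM to 60000 nM.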

Compound 3, half-maximal inhibitory concentration: 9800 nM
The estimate for compound 3 lay 2.0-fold (0.31 log units) above the measured number; the measured number falls inside the stated range.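

On this carbonyl carbon, 4-chloro-3-(trifluoromethyl)phenyl in place of 3,5-dichlorophenyl gives an at least 2.0-fold lower number from compound 2 to compound 3 (0.30 log units; that floor lies within the scatter), which provides a real number for an amide of this kind. As far as these compounds go, compound 2 holds a limit, not a number, so the true size of that step stays open: the limit of > 20000 nM in this assay, at which 1 of the 3 values shown sits. Dropping the amino nitrogen while keeping this aryl group gives a 1.4-fold lower number from compound 1 to compound 3 (0.15 log units; within the scatter), a difference that cannot be told from scatter.

Still open, from the compounds shown here alone, is what an amine or a carboxylic acid on the aryl ring would do, and whether any group on this carbonyl carbon can give much lower numbers.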